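A urea replaced by a benzamide on the shared core

The source may hold more compounds than are shown below. What is called first, only, known or untested is meant among the compounds shown, and "the series" means these compounds.

Compound 1 `COc1cc(-c2nn(-c3cccc(NC(=O)Nc4ccc(Cl)c(Cl)c4)c3)cc2-c2ccncc2)ccc1Cl` is the starting point of this comparison. In a functional assay on MDA-MB-231 cells (Homo sapiens) for inhibition, read by sulforhodamine B assay, with a stated time of 48 h (on this read-out lower numbers stand for higher toxicity in this test and higher numbers for lower toxicity in this test), compound 1 gives 12900 nM, the highest number among the two compounds with a measured value. Compound 3 `O=C(Nc1cccc(-n2cc(-c3ccncc3)c(-c3ccc(Cl)c(O)c3)n2)c1)Nc1cc(C(F)(F)F)cc(C(F)(F)F)c1` gives 3720 nM in this assay. Compound 2 `O=C(Nc1cccc(-n2cc(-c3ccncc3)c(-c3ccc(Cl)c(O)c3)n2)c1)Nc1ccc(Cl)c(Cl)c1` reaches only a limit of the assay, > 32500 nM, in this assay. Among the compounds with values here, the one step measured between neighbours, an at least 2.5-fold higher number from compound 1 to compound 2 (0.40 log units; beyond the scatter), runs into that limit, as noted in the limit of > 32500 nM in this assay, at which 1 of the 3 values shown sits.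

The unmeasured compound 4 `COc1cc(-c2nn(-c3cccc(NC(=O)c4ccccc4)c3)cc2-c2ccncc2)ccc1Cl` differs from compound 1 in a single place: phenyl in place of (3,4-dichlorophenyl)amino on a carbonyl carbon. Within the data shown here, none of the measured steps touches this carbonyl carbon; the measured change concerns the oxygen on an aromatic ring, so no measured step bears directly on the new change. Without a matching pair, the expectation for compound 4 can rest only on the value of compound 1, 12900 nM, and on the loss of the (3,4-dichlorophenyl)amino group, which in the shared core accompanies the numbers shown. For compound 4 a step of a 2.3-fold higher number from compound 1 to compound 4 (0.37 log units; beyond the scatter) is therefore expected, toward a higher number, with a fair chance that only a limit is reported. The estimate for compound 4 is 30000 nM, within a range from 8000 nM to 100000 nM.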

Compound 4, concentration lethal to 50% of the cells: > 100000 nM
Compound 4 gave a limit, no number (the forecaster's own chance of this, stated with the estimate: 45%); at least 3.3-fold (0.52 log units) between middle value and limit.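

Phenyl in place of (3,4-dichlorophenyl)amino on a carbonyl carbon is the first change shown at this position, and in this assay it gives an at least 7.7-fold higher number from compound 1 to compound 4 (0.88 log units; beyond the scatter). Compound 4 reaches only a limit of the assay, > 100000 nM, so the step has a lower bound but no exact size: the limit of > 100000 nM in this assay, at which 1 of the 4 values shown sits. The earlier step concerned only the methyl on an oxygen on an aromatic ring, whereas this one shows that, on the core of compound 1, the read-out also responds to the group on the carbonyl carbon, with lower toxicity in this test once the (3,4-dichlorophenyl)amino group is gone.

The change removes the amino nitrogen with its hydrogen-bond donor and the two chlorine atoms together, so the compounds shown cannot tell which of these parts goes with the difference. As far as these compounds go, a 3,4-dichlorophenyl group on the same carbonyl carbon, which keeps the chlorine atoms without the amino nitrogen, or an unsubstituted phenylamino group, which keeps the nitrogen without the chlorine atoms, would separate the two, and the effect of the same change on the hydroxy-bearing compound 2 also remains open.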